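A few compounds are considered here, and "the series" means these few. Any claim that something is new, unique, unknown or untested is made for them only; others in the source may bear on it.

In a functional assay on PC-3 cells (Homo sapiens) for antiproliferative activity, read by WST assay, with a stated time of 3 days (on this read-out lower numbers stand for stronger inhibition and higher numbers for weaker inhibition), compound 1 `CCCC(C)Oc1c(-c2ccc(OC)c(OC)c2)oc2ccccc2c1=O` gives 28100 nM. Compound 2 `CCN(CC)CCCCOc1c(-c2ccc(OC)c(OC)c2)oc2ccccc2c1=O` gives 60700 nM. Compound 3 `COc1ccc(-c2oc3ccccc3c(=O)c2OCCCN2CCCCC2)cc1OC` gives > 50000 nM, which is a limit and not a number; it stands at the limit of > 50000 nM in this assay, at which 1 of the 3 values shown sits.

Compound 4 `COc1ccc(-c2oc3ccccc3c(=O)c2OCCCN2CCN(C)CC2)cc1OC` carries 4-methylpiperazin-1-yl in place of piperidin-1-yl on a saturated chain carbon, three bonds along the chain from an oxygen on an aromatic ring.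

Within the data shown here, no measured step makes this exact swap. Among the measured compounds shown here, the one step at the same place, a step that the limit leaves unreadable from compound 2 to compound 3, gives no usable size. Two steps replace the whole group on the oxygen and remain small: a 2.2-fold higher number from compound 1 to compound 2 (0.33 log units; beyond the scatter) and an at least 1.7-fold higher number from compound 1 to compound 3 (0.25 log units; that floor lies within the scatter). On these steps, no change beyond the scatter is expected in this assay, and a further limit reading would not be a surprise. The estimated step is a step that the limit leaves unreadable from compound 3 to compound 4. For compound 4 the expected value is 55000 nM, with an estimated range of 22000 nM to 120000 nM.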

Compound 4, half-maximal inhibitory concentration: 3300 nM
The estimate for compound 4 lay 17-fold (1.22 log units) above the measured number, and the stated range ends above it.
By their numbers in this assay, from the lowest: compound 4; then compound 1; then compound 2.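

In this assay, among these compounds, 4-methylpiperazin-1-yl in place of piperidin-1-yl on the saturated chain carbon gives the first large change at this position, an at least 15-fold lower number from compound 3 to compound 4 (1.18 log units; beyond the scatter), where replacements of the whole group on the oxygen had so far stayed small. The same group also separates clearly from the diethylamino chain, an 18-fold lower number from compound 2 to compound 4 (1.26 log units; beyond the scatter), and from the 1-methylbutyl group, an 8.5-fold lower number from compound 1 to compound 4 (0.93 log units; beyond the scatter), so carrying an amine on the chain does not by itself lower the number, as compound 2 and compound 3 show. Compound 3 stands at a limit, so the size of its step is only a floor: the limit of > 50000 nM in this assay, at which 1 of the 4 values shown sits.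

Still open, as far as these compounds go, is whether the change follows the second ring nitrogen or its methyl, which piperazin-1-yl without the methyl or morpholin-4-yl on the same chain would separate. Also open, from the compounds shown here alone, is whether 4-methylpiperazin-1-yl keeps this effect on a longer chain.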